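A Side Chain Removed: Compound 1 to Compound 3

A few compounds are considered here, and "the series" means these few. Any claim that something is new, unique, unknown or untested is made for them only; others in the source may bear on it.

Compound 1 `COc1cc2c(Oc3ccc(NC(=O)c4nc(-c5ccc(F)cc5)no4)cc3)ccnc2cc1OCCCN1CCC(C)CC1`: 1040 nM in a functional assay on PC-3 cells (Homo sapiens) for antiproliferative activity, read by MTT assay, with a stated time of 72 h; a lower number here means a stronger inhibitor, a higher number a weaker inhibitor
Compound 2 `COc1cc2c(Oc3ccc(NC(=O)c4ncc(-c5ccc(F)cc5)o4)cc3)ccnc2cc1OCCCN1CCC(C)CC1`: 720 nM in this assay

Of the two numbers in this assay, compound 1 holds the highest, and compound 2 stands nearest to it; the step of a 1.4-fold lower number from compound 1 to compound 2 (0.16 log units; within the scatter) lies within the scatter, so the two compounds are not separated by this measurement. Compound 3 `COc1cc2nccc(Oc3ccc(NC(=O)c4nc(-c5ccc(F)cc5)no4)cc3)c2cc1OC` differs from compound 1 by hydrogen in place of 2-(4-methylpiperidin-1-yl)ethyl on a saturated chain carbon bound to an oxygen on an aromatic ring; cut one bond further out, the same change reads 3-(4-methylpiperidin-1-yl)propyl to methyl, or 3-(4-methylpiperidin-1-yl)propoxy to methoxy. Going by the values given here, no measured step bears on this place: the only step known, from compound 1 to compound 2, exchanges the group on the carbonyl carbon and leaves the side chain untouched, and it stays within the scatter. Among the compounds with values here, the expectation for compound 3 therefore rests on the change itself, with no measured precedent, and is held loosely. Compound 3 is expected to give a higher number in this assay, estimated at 2500 nM with a range from 800 nM to 8000 nM. The expected step is a 2.4-fold higher number from compound 1 to compound 3 (0.38 log units; beyond the scatter).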

Compound 3, half-maximal inhibitory concentration: > 100000 nM
Compound 3: a limit, no number (the forecaster's own chance of this, stated with the estimate: 10%); middle value at least 40-fold (1.60 log units) from the limit.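

In this assay, this position responds far more strongly than the group on the carbonyl carbon, where a 1.4-fold lower number from compound 1 to compound 2 (0.16 log units; within the scatter) left the two compounds unseparated. Here, the change from 3-(4-methylpiperidin-1-yl)propoxy to methoxy gives an at least 96-fold higher number from compound 1 to compound 3 (1.98 log units; beyond the scatter), so the side chain of compound 1 is not a part of the structure that can be exchanged freely for methoxy in this assay. The value of compound 3, > 100000 nM, is a limit of the assay and not a number, so the step marks only the smallest size the change can have, and how far compound 3 actually lies beyond it remains unknown: the limit of > 100000 nM in this assay, at which 1 of the 3 values shown sits.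

The compounds shown do not tell which part of the side chain matters at this place, whether the piperidine ring, its nitrogen, its methyl group or the propoxy chain itself. As far as these compounds go, a propoxy chain ending in a morpholine or a dimethylamine, or a plain propoxy chain with no amine, would help to separate these, and it also stays open whether the same change acts alike with the 5-(4-fluorophenyl)-1,3-oxazol-2-yl group of compound 2.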